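Halogen swap on the hydroxy-bearing ring: cytotoxicity notes

The compounds below may be only part of what the source reports. "The series", "measured", "known", "first", "only" and "open" are said of these compounds alone.

Measured so far:
compound 1 `O=C(Nc1ccc(C(F)(F)F)cc1)c1cc(Cl)ccc1O`, 2800 nM
compound 2 `O=C(Nc1ccc(F)c(Cl)c1)c1cc(Cl)ccc1O`, 4400 nM
compound 3 `O=C(Nc1ccc(F)c(F)c1)c1cc(Cl)ccc1O`, 7700 nM

In an ADME assay on cells (Macrophage, Mus musculus) for cytotoxicity, read by resazurin assay, with a stated time of 3 days (on this read-out lower numbers stand for stronger inhibition and higher numbers for weaker inhibition), compound 1 and compound 2 lie within the scatter of each other, while compound 3 lies beyond the scatter from compound 1. The difference between the core of compound 1 and the core of compound 2 is not broken down here.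

Within the pair that shares a core, the step from compound 2 to compound 3 is fluoro in place of chloro on an aromatic carbon and gave a 1.8-fold higher number from compound 2 to compound 3 (0.24 log units; within the scatter) in this assay.

Compound 4 `O=C(Nc1ccc(C(F)(F)F)cc1)c1cc(F)ccc1O` is not yet measured. It differs from compound 1 by fluoro in place of chloro on an aromatic carbon. This is the same kind of change as that from compound 2 to compound 3, not the same: in compound 4 the entering fluoro is para to a hydroxy group, whereas in compound 3 it is ortho to a fluoro group, with meta to a large group common to both.

The expectation for compound 4 is a 1.6-fold higher number from compound 1 to compound 4 (0.21 log units; within the scatter) in this assay, resting on a 1.8-fold higher number from compound 2 to compound 3 (0.24 log units; within the scatter). Compound 4 is estimated at 4500 nM, between 2000 nM and 10000 nM.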

Compound 4, half-maximal inhibitory concentration: 5400 nM
Beside the measured number, compound 4's estimate is 1.2-fold (0.08 log units) below it; the measured number falls inside the stated range.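

In this assay, fluoro in place of chloro on an aromatic carbon gave a 1.9-fold higher number from compound 1 to compound 4 (0.29 log units; within the scatter), and the step on the other core reads much the same: the same change on two cores in this assay, a 1.8-fold higher number (0.24 log units; within the scatter) from compound 2 to compound 3 and a 1.9-fold higher number (0.29 log units; within the scatter) from compound 1 to compound 4, 1.1-fold (0.04 log units) apart, within the scatter of two such steps. On these two cores, then, the change carries over with no difference that can be told apart, and both numbers move the same way. This does not show that the change has a real effect on this read-out, as each step on its own lies within the scatter; the two swaps also do not sit at the same place, and two cores make no rule for the series.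

The compounds shown leave open how the number responds when the halogen gives way to a group of another kind, such as a nitrile or a methoxy group. Also open, going by these compounds, is what an amine or a carboxylic acid would do in place of the trifluoromethyl group, and whether the hydroxy group is needed at all.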